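Benzyl group exchange on the shared core: compound 2 to compound 3

The source may hold more compounds than are shown below. What is called first, only, known or untested is meant among the compounds shown, and "the series" means these compounds.

Measured so far in a physicochemical assay for solubility (a higher number here means a more soluble compound, a lower number a less soluble compound), for two compounds
- Compound 1 `O=C(O)c1ccc(C(=O)/C(=C\c2ccc(Cl)c([N+](=O)[O-])c2)SCc2ccccc2F)cc1` gives < 1000 ug/mL as a limit
- Compound 2 `O=C(O)c1ccc(C(=O)/C(=C\c2ccc(Cl)c([N+](=O)[O-])c2)S(=O)(=O)Cc2ccc(Br)cc2)cc1` gives < 1000 ug/mL as a limit

In this assay compound 2 has only the limit < 1000 ug/mL and no number. Among the compounds with values here, the series so far holds the limit of < 1000 ug/mL in this assay, at which 2 of the 2 values shown sit, and nothing firmer.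

Compound 3 `O=C(O)c1ccc(C(=O)/C(=C\c2ccc(Cl)c([N+](=O)[O-])c2)SCc2ccc(Cl)cc2Cl)cc1` brings (2,4-dichlorobenzyl)sulfanyl in place of (4-bromobenzyl)sulfonyl on a double-bonded chain carbon bound to a carbonyl carbon and a double-bonded chain carbon, with (2,4-dichlorobenzyl)sulfanyl in place of (4-bromobenzyl)sulfonyl on a double-bonded chain carbon bound to a carbonyl carbon and a double-bonded chain carbon as the full difference.

Within the data shown here, the one measured step at this place is a step that the two limits leave unreadable from compound 1 to compound 2 and it is the only guide. Compound 1 carries a sulfanyl group, as compound 3 does, yet that step offers no size and no direction to carry over. The step expected is therefore a step that the limit leaves unreadable from compound 2 to compound 3 as an estimate with no firm direction. Another limit is the likeliest report for compound 3. For compound 3 the estimated value in this assay is 200 ug/mL with an expected range of 20 ug/mL to 1000 ug/mL as a rough guide.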

Compound 3, solubility: < 1000 ug/mL
Compound 3 was reported as a limit; the forecaster's own chance of this, stated with the estimate: 85%; the middle value lies beyond the limit too.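

In this assay compound 3 gives < 1000 ug/mL, a limit and not a number. Within the data shown here, no step among compound 1, compound 2 and compound 3 can be read. Still open is whether any exchange of the benzyl group on the shared core changes the result in this assay, and in which direction, as the series holds only: the limit of < 1000 ug/mL in this assay, at which 3 of the 3 values shown sit.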